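The compounds below may be only part of what the source reports. "The series", "measured", "known", "first", "only" and "open" are said of these compounds alone.

Of the compounds shown here, three share a common core and have been tested in a functional assay on the whole organism (Tail, strain ICR) with Mus musculus as the target, in the tail flick test, with a stated time of 150 min, at a dose of 25 umol/kg by the oral route; on this read-out higher numbers stand for a stronger effect at the one dose given and lower numbers for a weaker effect. Compound 1, `N=C(N)NCCC[C@H](NC(=O)CN(c1ncnc2c1ncn2C1CCCCO1)C1CC1)C(=O)OCc1ccccc1`, gives 19.6% in this assay. Compound 2, `CSCC[C@H](NC(=O)CN(c1nc(Cl)nc2[nH]cnc12)C1CC1)C(=O)OCc1ccccc1`, gives 17.6% in this assay. Compound 3, `C[C@H](NC(=O)CN(c1nc(Cl)nc2[nH]cnc12)C1CC1)C(=O)O`, gives 14.7% in this assay. All three numbers lie close together: the gap from compound 2 to compound 1 and the gap from compound 2 to compound 3 both fall within the usual scatter of repeated measurements, so none of the three can be said to stand apart from the others, and compound 2 sits among them with no clear separation.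

The new compound is compound 4, `CC[C@H](C)[C@H](NC(=O)CN(c1nc(Cl)nc2[nH]cnc12)C1CC1)C(=O)OCc1ccccc1`. It differs from compound 2 in one place: sec-butyl in place of 2-(methylsulfanyl)ethyl on a saturated chain carbon bound to an amide-type nitrogen and a carbonyl carbon. Among the three measured compounds, changes at this same position, and also at the core, leave the numbers inside the scatter, so no measured step gives a direction for this new change. The step from compound 2 to compound 4 is therefore expected to be small, with no direction beyond the scatter, which the expected step of a number 0.4 percentage points higher from compound 2 to compound 4 (within the scatter) reflects. On that basis compound 4 is estimated to give 18% in this assay, with a range from 8% to 28%.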

Compound 4, a percentage reported as activity, at one dose (the size of the read-out at that dose, not a potency): 6.9%
For compound 4 the middle estimate is 11.1 percentage points above the measured one, outside the stated range (below it).
By their numbers in this assay, from the lowest: compounds 4, 3, 2 and 1 (each within the scatter of the next, the first and the last beyond it).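

In this assay, among the compounds shown here, putting sec-butyl in place of 2-(methylsulfanyl)ethyl on a saturated chain carbon bound to an amide-type nitrogen and a carbonyl carbon gives a number 10.7 percentage points lower from compound 2 to compound 4 (beyond the scatter), the only step between two compounds that differ in one place, and it lies beyond the scatter. This shows that the read-out does respond to this position, even though each of the two groups has 4 heavy atoms, no ring and no net charge; what changes in the count is that sulfur gives way to carbon, the hydrogen-bond acceptor is lost and a defined stereocentre enters. Nothing measured here explains why the number falls, so the step stands as an observation only.

The compounds shown leave open which of those differences goes with the lower number, since a straight n-butyl chain or a 2-methoxyethyl group at this position would be needed to pull them apart. They also leave open how a chain ending in an amine or a carboxylic acid would behave here, with the shared core and the benzyl ester kept the same.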